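Chloro in Place of Hydrogen on a Thiazole-Type Core

The source may hold more compounds than are shown below. What is called first, only, known or untested is meant among the compounds shown, and "the series" means these compounds.

Measured compounds:
- compound 1, `FC(F)=C(F)CCSc1nc2ccccc2s1`: > 120000 nM in this assay
- compound 2, `FC(F)=C(F)CCSc1nccs1`: > 120000 nM in this assay

Of the compounds shown here, two have been measured in a functional assay on HepG2 cells (Homo sapiens) for cytotoxicity, read by MTT assay, with a stated time of 48 h; on this read-out higher numbers stand for weaker inhibition and lower numbers for stronger inhibition. Compound 1 is `FC(F)=C(F)CCSc1nc2ccccc2s1`. In this assay compound 1 gives > 120000 nM, which is a limit of the assay rather than a number. Compound 2 is `FC(F)=C(F)CCSc1nccs1`. In this assay compound 2 gives > 120000 nM, again a limit and not a number. Compound 2 therefore cannot be placed above or below compound 1; both sit at the same limit, as the limit of > 120000 nM in this assay, at which 2 of the 2 values shown sit, shows.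

Compound 3 is `FC(F)=C(F)CCSc1ncc(Cl)s1`. It differs from compound 2 by chloro in place of hydrogen on an aromatic carbon. Among the compounds with values here, no measured pair here shows what such a change does in this assay. With both measured compounds at the limit, there is no ground to expect any step beyond the scatter; the expectation is that compound 3 also stays near or beyond that limit, with the step estimated as a step that the limit leaves unreadable from compound 2 to compound 3. Compound 3 is thus estimated at 150000 nM, within 50000 nM to 450000 nM.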

Compound 3, half-maximal inhibitory concentration: > 120000 nM
Compound 3 ended at the assay's limit; the forecaster's own chance of this, stated with the estimate: 75%; the middle value lies beyond the limit too.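

Compound 2 and compound 3 both end at a limit of the assay rather than at a number, so no step between them can be read: the limit of > 120000 nM in this assay, at which 3 of the 3 values shown sit.

It remains open whether chloro in place of hydrogen on an aromatic carbon changes the result in this assay at all, and at what concentration any of these compounds would reach half-maximal inhibition.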